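A Chloro Substituent Tested on Two Related Cores

This account rests on a few compounds, and the source may have more. Where it says the series, first, only, none or still open, it means among the compounds named here.

Compound 1 `N#Cc1c(-c2nnc(-c3nn(-c4ccccc4)c(-c4ccccc4)c3C#N)c3nn(-c4ccccc4)cc23)nn(-c2ccccc2)c1-c1ccccc1` and compound 2 `N#Cc1c(-c2nnc(-c3nn(-c4ccccc4)c(-c4ccccc4)c3C#N)c3nn(-c4ccc(Cl)cc4)cc23)nn(-c2ccccc2)c1-c1ccccc1` share one core and differ only by chloro in place of hydrogen on an aromatic carbon. In a functional assay on T47D cells (Homo sapiens) for inhibition, read by sulforhodamine B assay, with a stated time of 48 h (on this read-out lower numbers stand for stronger inhibition of growth and higher numbers for weaker inhibition of growth), compound 1 gives 81000 nM, whereas compound 2 gives 16000 nM; that change produced a 5.1-fold lower number from compound 1 to compound 2 (0.70 log units; beyond the scatter). Compound 3 `N#Cc1c(-c2nnc(-c3ccccc3)c3nn(-c4ccccc4)cc23)nn(-c2ccccc2)c1-c1ccccc1` is built on a smaller core; how its core differs from the core of compound 1 is not broken down here. In this assay compound 3 gives 21800 nM, a number that lies within the scatter of compound 2 and well below that of compound 1.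

Compound 4 `N#Cc1c(-c2nnc(-c3ccccc3)c3nn(-c4ccc(Cl)cc4)cc23)nn(-c2ccccc2)c1-c1ccccc1` has not yet been measured. It differs from compound 3 by chloro in place of hydrogen on an aromatic carbon, the same change, at the same place, as that from compound 1 to compound 2. Because a 5.1-fold lower number from compound 1 to compound 2 (0.70 log units; beyond the scatter) was observed on a different core, that step serves as a guide rather than a rule, and a somewhat smaller effect is expected here. Compound 4 is therefore expected to give about 7000 nM in this assay, with a plausible range from 3000 nM to 20000 nM. This corresponds to an expected 3.1-fold lower number from compound 3 to compound 4 (0.49 log units; beyond the scatter).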

Compound 4, concentration for 50% growth inhibition: 38000 nM
Beside the measured number, compound 4's estimate is 5.4-fold (0.73 log units) below it; the whole stated range lies below it.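

Within the data shown here, on the smaller core, chloro in place of hydrogen gave a 1.7-fold higher number from compound 3 to compound 4 (0.24 log units; within the scatter) in this assay, so the phenyl to 4-chlorophenyl change left no step that can be told apart from the scatter. Set beside the earlier result, the same change clearly behaves differently on the two cores: the same change on two cores in this assay, a 5.1-fold lower number (0.70 log units; beyond the scatter) from compound 1 to compound 2 and a 1.7-fold higher number (0.24 log units; within the scatter) from compound 3 to compound 4, 8.8-fold (0.95 log units) apart, beyond the scatter of two such steps. This shows that the gain seen on the core of compound 1 did not carry over to the core of compound 3 in this assay, but with one pair on each core it does not show why the two differ, nor how the change would behave on any further core.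

The compounds shown leave open whether this dependence on the core is peculiar to chloro or would also appear with other groups at the same place, such as bromo, methoxy, an amine or a carboxylic acid. They also leave open whether the same split between the two cores would hold in cell lines other than this one.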